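Acetyl for Methyl on the Ring Amine of Compound 3

The source may hold more compounds than are shown below. What is called first, only, known or untested is meant among the compounds shown, and "the series" means these compounds.

Compound 3 `CN1CCN(c2cn(S(=O)(=O)c3ccccc3)c3ccccc23)CC1` gives 4 nM in an assay on isolated protein for displacement of a labelled ligand from 5-hydroxytryptamine receptor 6 (Homo sapiens), read by scintillation counting, with a stated time of 1 h (a lower number here means a stronger inhibitor, a higher number a weaker inhibitor), the lowest of the three numbers recorded. Compound 1 `O=S(=O)(c1ccccc1)n1ccc2c(O)cccc21` gives 108 nM in this assay, and compound 2 `COc1cccc2c1ccn2S(=O)(=O)c1ccccc1` gives 262 nM in this assay. Among the measured compounds shown here, the only one-place step among the measured compounds, a 2.4-fold higher number from compound 1 to compound 2 (0.38 log units; beyond the scatter), concerns a methyl on an oxygen of an aromatic ring and does not touch the ring amine. Compound 4 `CC(=O)N1CCN(c2cn(S(=O)(=O)c3ccccc3)c3ccccc23)CC1` differs from compound 3 by acetyl in place of methyl on an amine nitrogen in a ring. For the measured compounds named here, no measured step bears directly on this change, so the expectation rests on compound 3 alone and is held loosely. A rise toward a higher number is expected, the estimated step being a 10-fold higher number from compound 3 to compound 4 (1.00 log units; beyond the scatter). Compound 4 is thus expected to give about 40 nM, between 8 nM and 250 nM.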

Compound 4, inhibition constant: 97 nM
Compound 4: middle estimate off by 2.4-fold (0.38 log units), on the low side, and the stated range covers the measured number.
By their numbers in this assay, from the lowest: compound 3; then compounds 4 and 1 (each within the scatter of the next); then compound 2.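

Placing acetyl for methyl on the amine nitrogen in the ring gives, in this assay, a 24-fold higher number from compound 3 to compound 4 (1.38 log units; beyond the scatter), a large step. Among the compounds shown here, this is the first measured sign that the group on this ring nitrogen matters, since the earlier step concerned a methyl on an oxygen of an aromatic ring. Nothing available accounts for the size of this step. The compounds shown leave open how the bare amine hydrogen, an ethyl or a longer chain would compare on this nitrogen, and whether a urea or a sulfonamide there would follow acetyl.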